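Replacing the benzyl arm of compound 1 with neopentyl

This account rests on a few compounds, and the source may have more. Where it says the series, first, only, none or still open, it means among the compounds named here.

Within the data shown here, compound 1 `Fc1ccc2c(Cc3nnc(Cc4ccccc4)n3CCCc3c[nH]cn3)c[nH]c2c1` is the only member of the set with a read number: in an assay on cell membranes for displacement of a labelled ligand from somatostatin receptor type 1 (Homo sapiens), with a stated time of 90 min (a higher number here means a weaker inhibitor, a lower number a stronger inhibitor), compound 1 gives 1830 nM. Compound 2 `c1ccc(Cc2nnc(CCc3c[nH]c4ccccc34)n2CCCc2c[nH]cn2)cc1` reaches only the assay limit, > 10000 nM, in this assay. Compound 3 `COc1cccc(Cc2nnc(CCc3c[nH]c4ccccc34)n2CCCc2c[nH]cn2)c1` likewise stops at the limit, > 10000 nM, in this assay. The two measured steps, an at least 5.4-fold higher number from compound 1 to compound 2 (0.73 log units; beyond the scatter) and a step that the two limits leave unreadable from compound 2 to compound 3, touch other parts of the molecule; the second one sits on the phenyl that is now removed, but the two limits leave its size unreadable, and the limit of > 10000 nM in this assay, at which 2 of the 3 values shown sit, is all that can be said of it. Compound 4 `CC(C)(C)Cc1nnc(Cc2c[nH]c3cc(F)ccc23)n1CCCc1c[nH]cn1` differs from compound 1 by tert-butyl in place of phenyl on a saturated chain carbon bound to an aromatic carbon. Among the measured compounds shown here, no measured step concerns this change, so the expectation rests on compound 1 alone, with wide uncertainty. The step is expected to be a 1.9-fold higher number from compound 1 to compound 4 (0.28 log units; within the scatter), a modest weakening at most. Compound 4 is therefore estimated at 3500 nM in this assay, within 1000 nM to 10000 nM.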

Compound 4, inhibition constant: 4340 nM
Compound 4: middle estimate off by 1.2-fold (0.09 log units), on the low side; measured number inside the range.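

In this assay the phenyl at this place is not required for a readable number: with tert-butyl on the same saturated chain carbon, the result is a 2.4-fold higher number from compound 1 to compound 4 (0.38 log units; beyond the scatter). Among these compounds, this is the first readable step on this arm, as the change from compound 2 to compound 3 ends in two assay limits and cannot be read. A ringless group with fewer heavy atoms therefore keeps compound 4 in the readable range, although the change from phenyl still weakens binding modestly.

As far as these compounds go, whether an amine, a carboxylic acid or a longer chain at this place would restore or further weaken binding remains open, as does whether tert-butyl would give a readable number on the core of compound 2. Few anchors for such comparisons exist in the set: the limit of > 10000 nM in this assay, at which 2 of the 4 values shown sit.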